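This account rests on a few compounds, and the source may have more. Where it says the series, first, only, none or still open, it means among the compounds named here.

Compound 1 `COc1ccc2nc(NC(=O)c3cc(-c4ccc(OC)c(OC)c4)n4nc(-c5ccccc5)cc4n3)sc2c1`: in a functional assay on ACHN cells (Homo sapiens) for cytotoxicity, read by MTT assay, with a stated time of 48 h (on this read-out higher numbers stand for weaker inhibition and lower numbers for stronger inhibition), compound 1 gives 13300 nM.
Compound 2 `COc1ccc(-c2cc(C(=O)Nc3nc4ccccc4s3)nc3cc(-c4ccccc4)nn23)cc1`: in this assay compound 2 gives 1690 nM.

Among the measured compounds shown here, of the two numbers known in this assay, compound 2 holds the lower one, and the gap to compound 1 lies beyond the usual scatter of repeated measurements. Compound 3 `COc1ccc(-c2cc(C(=O)Nc3nc4ccccc4s3)nc3cc(-c4ccccc4)nn23)cc1OC` is not yet measured. It differs from compound 2 in one place: methoxy in place of hydrogen on an aromatic carbon. For the measured compounds named here, compound 1 carries the same 3,4-dimethoxyphenyl group but also a further methoxy group, so the two measured compounds differ in two places and no single step between them can be read; their values show only that the compound carrying the 3,4-dimethoxyphenyl group together with the further methoxy group gives the higher number. On that basis a moderate rise in the number, that is weaker inhibition, is expected for compound 3 in this assay, though a value unchanged within the scatter is also possible. Compound 3 is expected to give 3500 nM, within a range from 1200 nM to 12000 nM, the expected step being a 2.1-fold higher number from compound 2 to compound 3 (0.32 log units; beyond the scatter).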

Compound 3, half-maximal inhibitory concentration: 7940 nM
For compound 3 the middle estimate is 2.3-fold (0.36 log units) below the measured one; the range from low to high includes it.
By their numbers in this assay, from the lowest: compound 2; then compounds 3 and 1 (each within the scatter of the next).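

In this assay, the change from 4-methoxyphenyl to 3,4-dimethoxyphenyl gives a 4.7-fold higher number from compound 2 to compound 3 (0.67 log units; beyond the scatter), which is weaker inhibition, so this aromatic carbon, ortho to a methoxy group, does not tolerate the added methoxy without a loss beyond the scatter. Compound 1 and compound 3 differ only in the further methoxy group on the other side of the amide, and the step between them, a 1.7-fold lower number from compound 1 to compound 3 (0.22 log units; within the scatter), shows that this further group makes no difference that can be told apart from the scatter, so of the two places that separate compound 1 from compound 2, only the 3,4-dimethoxyphenyl change has a step beyond the scatter. Nothing given here bears on why the added methoxy has this effect.

From the compounds shown here alone, it remains open whether a hydroxyl group, a fluorine atom or an ethoxy chain on the same aromatic carbon would give a similar rise in the number. Going by these compounds, it also remains open whether the rise depends on the methoxy group already present on that ring.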